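Swapping amino for trifluoromethyl on a guanidine carbonyl

The source may report more compounds than this note shows. Statements on the series, on what has been measured and on what is new or still open speak of the compounds shown alone.

Measured so far in a functional assay on the whole organism (blood, strain Wistar-Okamoto) with Rattus norvegicus as the target, with a stated time of 5 days; on this read-out lower numbers stand for an effect already at smaller amounts and higher numbers for an effect only at larger amounts of compound:
compound 1 `CCC(C)(C)/N=C(\NC#N)Nc1ccncc1` gives 2.5 mg/kg
compound 2 `Cc1nn(C)c(C)c1N/C(=N/C#N)NC(C)(C)C` gives 5 mg/kg
compound 3 `CCC(C)(C)N/C(=N\C(N)=O)Nc1cccnc1` gives > 50 mg/kg

Compound 1 and compound 2 both carry a nitrile on the guanidine and both show an effect in this assay at small amounts. Compound 3 is different: its reading is only a limit of the assay, not a number, and it sits at the limit of > 50 mg/kg in this assay, at which 1 of the 3 values shown sits. So compound 3 stands apart from the other two, with no effect seen at any amount actually tested.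

Compound 4 `CCC(C)(C)N/C(=N\C(=O)C(F)(F)F)Nc1cccnc1` has not yet been tested in this assay. It differs from compound 3 in one place: trifluoromethyl in place of amino on a carbonyl carbon. Among the measured compounds shown here, no pair of measured compounds shows exactly this change, so there is no measured step to lean on, and the value of compound 3 being a limit makes the size of any step uncertain.

Compound 4 is expected to move toward an effect at smaller amounts, with a step from compound 3 estimated as an at least 3.3-fold lower number from compound 3 to compound 4 (0.52 log units; beyond the scatter). Compound 4 is estimated at 15 mg/kg, within a range from 3 mg/kg to 50 mg/kg.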

Compound 4, minimum effective dose: > 50 mg/kg
Compound 4: no number, only a limit; the forecaster's own chance of this, stated with the estimate: 40%; middle value at least 3.3-fold (0.52 log units) from the limit.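

In this assay compound 4 gives > 50 mg/kg, which is a limit of the assay and not a number. Compound 3 also gives only a limit, so no step from one to the other can be read: the limit of > 50 mg/kg in this assay, at which 2 of the 4 values shown sit.

On these data alone, whether trifluoromethyl in place of amino on this carbonyl carbon changes the dose needed at all remains open.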